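The source may hold more compounds than are shown below. What is called first, only, known or untested is meant among the compounds shown, and "the series" means these compounds.

Measured so far:
compound 1, `CCCCCCCCCCc1ccc(-c2noc(CCCN)n2)cc1` — 67%
compound 2, `CCCCCCCCCCc1ccc(-c2noc([C@@H](N)CCCCN)n2)cc1` — 43%

In an assay on HeLa cells for inhibition of sphingosine-1-phosphate transporter SPNS2 (Mus musculus), read by LC-MS, tested at 2 uM (a lower number here means less inhibition, a higher number more inhibition at the concentration tested (going by the name of the read-out)), compound 1 gives 67% and stands highest of the two numbers. Compound 2 gives 43%; the step of a number 24 percentage points lower from compound 1 to compound 2 (beyond the scatter) is beyond the scatter and goes with 1,5-diaminopentyl in place of 3-aminopropyl on an aromatic carbon.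

Compound 3, `CCCCCCCCCCCc1ccc(-c2noc(CCCN)n2)cc1`, is not yet measured. It differs from compound 1 by methyl in place of hydrogen on a saturated chain carbon, ten or more bonds along the chain from an aromatic carbon. Among the compounds with values here, the only measured step concerns the amine-bearing side chain, not the alkyl chain, so no measured step bears on this change; the size of the step in this assay cannot be read from the two measured compounds. With nothing to indicate a shift, a step within the scatter is the expectation, a number 1 percentage points higher from compound 1 to compound 3 (within the scatter). Compound 3 is therefore estimated at 68%, in the range 50% to 85%.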

Compound 3, a percentage reported as inhibition, at one concentration (the size of the read-out at that concentration, not a potency): 49%
Beside the measured number, compound 3's estimate is 19 percentage points above it, outside the stated range (below it).
By their numbers in this assay, from the lowest: compounds 2 and 3 (each within the scatter of the next); then compound 1.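

In this assay, the far end of the alkyl chain proves sensitive: methyl in place of hydrogen on a saturated chain carbon, ten or more bonds along the chain from an aromatic carbon, gives a number 18 percentage points lower from compound 1 to compound 3 (beyond the scatter). The earlier compounds shown here showed a change only on the amine-bearing side chain, with a number 24 percentage points lower from compound 1 to compound 2 (beyond the scatter), whereas here 1 heavy atom at the opposite end of the molecule is enough to move the read-out beyond the scatter. Nothing at hand bears on the reason for this step.

As far as these compounds go, a single added carbon gives no trend, so the response to a shorter chain such as octyl or a longer chain such as dodecyl remains open. Also open, from the compounds shown here alone, is whether the same chain extension has a similar effect alongside the 1,5-diaminopentyl side chain.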